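The compounds below may be only part of what the source reports. "The series", "measured", "known", "first", "only" and "open" are said of these compounds alone.

Compound 1 `O=C(Nc1ccccc1)c1cc2cnc(Nc3ccc(N4CCNCC4)cn3)nc2n1C1CCCC1`: 2800 nM
Compound 2 `COc1cccc(NC(=O)c2cc3cnc(Nc4ccc(N5CCNCC5)cn4)nc3n2C2CCCC2)c1`: 2650 nM
Compound 3 `COc1ccc(NC(=O)c2cc3cnc(Nc4ccc(N5CCNCC5)cn4)nc3n2C2CCCC2)cc1`: 2880 nM

These three values come from a functional assay on MIA PaCa-2 cells (Homo sapiens) for inhibition, read by MTT assay; a lower number here means a stronger inhibitor, a higher number a weaker inhibitor. With a 4-methoxyphenyl on an amide-type nitrogen, compound 3 gives 2880 nM, level with the other two compounds, since its steps to both lie within the usual scatter.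

The next compound, compound 4 `O=C(Nc1ccccc1Cl)c1cc2cnc(Nc3ccc(N4CCNCC4)cn3)nc2n1C1CCCC1`, has not yet been measured. It carries 2-chlorophenyl in place of 4-methoxyphenyl on an amide-type nitrogen.

Going by the values given here, three measured steps bear on this change, as each alters the group on that same nitrogen. Methoxy in place of hydrogen gave a 1.1-fold lower number from compound 1 to compound 2 (0.02 log units; within the scatter) and also a 1.0-fold higher number from compound 1 to compound 3 (0.01 log units; within the scatter). Then 4-methoxyphenyl in place of 3-methoxyphenyl gave a 1.1-fold higher number from compound 2 to compound 3 (0.04 log units; within the scatter). All three steps are small, so the measured compounds have so far shown no response to changes in this group. Still, none of them carries chlorine, so the evidence is indirect and the range should stay wide.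

The expected change is a 1.0-fold lower number from compound 3 to compound 4 (0.01 log units; within the scatter), which would be no step beyond the scatter. For compound 4 the estimated value is 2800 nM, with an expected range from 1400 nM to 5500 nM.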

Compound 4, half-maximal inhibitory concentration: 2170 nM
The estimate for compound 4 lay 1.3-fold (0.11 log units) above the measured number; measured number inside the range.
By their numbers in this assay, from the lowest: compounds 4, 2, 1 and 3 (each within the scatter of the next).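

Chlorine now joins methoxy among the groups tested on the aromatic ring of the amide, and in this assay replacing 4-methoxyphenyl with 2-chlorophenyl gives a 1.3-fold lower number from compound 3 to compound 4 (0.12 log units; within the scatter), while replacing 3-methoxyphenyl with it gives a 1.2-fold lower number from compound 2 to compound 4 (0.09 log units; within the scatter). Measured against the plain phenyl group, adding the chloro group gives a 1.3-fold lower number from compound 1 to compound 4 (0.11 log units; within the scatter), so this position has now tolerated a halogen as well as a methoxy group without a step beyond the scatter. Nothing measured here offers an explanation for this flat response.

On these data alone, all four compounds keep an aromatic ring on the amide nitrogen, bearing only hydrogen, methoxy or chloro, so it remains open whether an amine or a carboxylic acid on that ring, or a longer alkyl chain in place of the ring, would move the number beyond the scatter. Also open, as far as these compounds go, is whether changes to the shared core would matter more than changes to this amide group, as the core stays the same throughout these compounds.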